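Aryl alkyne propanoic acids: the ring substituent on the far ring

This account rests on a few compounds, and the source may have more. Where it says the series, first, only, none or still open, it means among the compounds named here.

In an in vitro functional assay on 1321-N1 cells for agonist activity at Free fatty acid receptor 1 (Homo sapiens), read by fluorescence (a higher number here means that more compound is needed for the effect, a lower number that less compound is needed), compound 3 `O=C(O)CCc1ccc(C#Cc2cccc(CO)c2)cc1` gives 891 nM, the highest of the two numbers; compound 2 `C#Cc1cccc(C#Cc2ccc(CCC(=O)O)cc2)c1` gives 155 nM, and compound 1 `O=C(O)CCc1ccc(C#Cc2ccccc2)cc1` gives 95.5 nM; 96 nM (2 entries), reproducible across its repeats (the several entries of compound 1 in this assay, 95.5 nM; 96 nM (2 entries)). Within the data shown here, the one step on this position, a 5.7-fold higher number from compound 2 to compound 3 (0.76 log units; beyond the scatter), is modest. Compound 4 `N#Cc1cccc(C#Cc2ccc(CCC(=O)O)cc2)c1` differs from compound 3 by cyano in place of hydroxymethyl on an aromatic carbon. Cyano, like ethynyl, carries no hydrogen-bond donor, and both are triple-bonded groups of two heavy atoms, so the hydroxymethyl-to-ethynyl step a 5.7-fold higher number from compound 2 to compound 3 (0.76 log units; beyond the scatter) is the closest guide, reversed in direction. A lower number than that of compound 3 is therefore expected, though perhaps not all the way back. The expected step is a 3.6-fold lower number from compound 3 to compound 4 (0.55 log units; beyond the scatter). For compound 4 in this assay the estimate is 250 nM, within 100 nM to 650 nM.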

Compound 4, half-maximal effective concentration: 91.2 nM
Compound 4: the middle estimate sits 2.7-fold (0.44 log units) above what was measured; measured number below the stated range.
By their numbers in this assay, from the lowest: compounds 4 and 2 (each within the scatter of the next); then compound 3.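

In this assay, replacing hydroxymethyl with cyano gives a 9.8-fold lower number from compound 3 to compound 4 (0.99 log units; beyond the scatter), so a second group now sits clear of hydroxymethyl at this place. Cyano and ethynyl are not separated here, with a 1.7-fold lower number from compound 2 to compound 4 (0.23 log units; within the scatter). Hydroxymethyl carries a hydrogen-bond donor and cyano none, but no measurement shown gives a reason for the step.

On these data alone, whether that donor is what sets hydroxymethyl apart stays open. An amine, a carboxylic acid or a methoxy group on the same aromatic carbon would bear on this.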